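The source may report more compounds than this note shows. Statements on the series, on what has been measured and on what is new or still open speak of the compounds shown alone.

Measured so far:
compound 1 `Cc1ccc(NC(=O)Nc2nnc(Sc3ncnc4scc(-c5ccncc5)c34)s2)cc1`: 17800 nM
compound 2 `O=C(Nc1ccc(Cl)cc1)Nc1nnc(Sc2ncnc3scc(-c4ccncc4)c23)s1`: 23300 nM

In a functional assay on T47D cells (Homo sapiens) for antiproliferative activity, read by MTT assay, with a stated time of 48 h (a lower number here means a stronger inhibitor, a higher number a weaker inhibitor), compound 1 gives 17800 nM and compound 2 gives 23300 nM. Going by the values given here, compound 2 stands at one end of the two numbers, with compound 1 its only neighbour, and the step of a 1.3-fold higher number from compound 1 to compound 2 (0.12 log units; within the scatter) leaves the pair within the scatter of each other. Compound 3 `O=C(Nc1ccc(Cl)c(C(F)(F)F)c1)Nc1nnc(Sc2ncnc3scc(-c4ccncc4)c23)s1` is the unmeasured member; relative to compound 2 the change is trifluoromethyl in place of hydrogen on an aromatic carbon. Among the compounds with values here, no measured step covers this addition. Within the data shown here, the single step recorded, methyl to chloro on the same ring, stayed within the scatter, which shows only that the two ring substituents tried so far give about the same number and says nothing about a second substituent. Among the measured compounds shown here, on that basis the expected step of a 1.2-fold lower number from compound 2 to compound 3 (0.07 log units; within the scatter) is one of no clear direction, with a wide range because the series offers no precedent for a second group on this ring. For compound 3 the estimate is 20000 nM, from 7000 nM to 55000 nM.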

Compound 3, half-maximal inhibitory concentration: 28000 nM
For compound 3 the middle estimate is 1.4-fold (0.15 log units) below the measured one; the measured number falls inside the stated range.
By their numbers in this assay, from the lowest: compounds 1, 2 and 3 (each within the scatter of the next).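

In this assay, the first second substituent on this ring, a trifluoromethyl ortho to a chloro group and meta to a large group, gives a 1.2-fold higher number from compound 2 to compound 3 (0.08 log units; within the scatter), so 4 heavy atoms can enter here in place of a hydrogen without the number leaving the scatter around compound 2. The largest difference on this aromatic ring among the compounds shown, 4-chloro-3-(trifluoromethyl)phenyl in place of 4-methylphenyl, gives a 1.6-fold higher number from compound 1 to compound 3 (0.20 log units; within the scatter), so the pair at the two ends of the series also stays unresolved, and no ring substituent tried so far separates any of the three compounds. Nothing at hand gives a measured reason for this flat picture.

Open, as far as these compounds go, is whether a group of another kind on this ring, such as an amine, a carboxylic acid or a longer alkyl chain, would move the number in this assay beyond the scatter. Also open, from the compounds shown here alone, is whether any change to the shared core would do so, since all three compounds carry the same core and differ only in this ring.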